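The source may report more compounds than this note shows. Statements on the series, on what has been measured and on what is new or still open speak of the compounds shown alone.

Compound 1 `COc1cc2nccc(Oc3ccc(NC(=O)c4nnc(-c5ccc(F)cc5)o4)cc3)c2cc1OC` gives the highest number of the three measured compounds in a functional assay on HT-29 cells (Homo sapiens) for antiproliferative activity, read by MTT assay, with a stated time of 72 h (on this read-out lower numbers stand for stronger inhibition and higher numbers for weaker inhibition), at 52300 nM; compound 3 `COc1cc2c(Oc3ccc(NC(=O)c4nnc(-c5ccc(F)cc5)o4)cc3)ccnc2cc1OCCCN1CCC(C)CC1` gives 7890 nM and compound 2 `COc1cc2c(Oc3ccc(NC(=O)c4ncc(-c5ccc(F)cc5)o4)cc3)ccnc2cc1OCCCN1CCC(C)CC1` gives 1890 nM. Compound 4 `COc1cc2nccc(Oc3ccc(NC(=O)c4cc(-c5ccc(F)cc5)on4)cc3)c2cc1OC` keeps the core of compound 1 and differs only in the group on the carbonyl carbon: 5-(4-fluorophenyl)-1,2-oxazol-3-yl in place of 5-(4-fluorophenyl)-1,3,4-oxadiazol-2-yl on a carbonyl carbon. For the measured compounds named here, the one measured step that bears on this change is a 4.2-fold higher number from compound 2 to compound 3 (0.62 log units; beyond the scatter), where the 5-(4-fluorophenyl)-1,3,4-oxadiazol-2-yl is the weaker partner; the step of a 6.6-fold lower number from compound 1 to compound 3 (0.82 log units; beyond the scatter) concerns another site and does not inform it. If the 5-(4-fluorophenyl)-1,2-oxazol-3-yl behaves like the other ring with two hetero atoms, a modest lowering is expected, a 3.1-fold lower number from compound 1 to compound 4 (0.49 log units; beyond the scatter). Compound 4 is therefore estimated at 17000 nM, with a range from 6000 nM to 50000 nM.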

Compound 4, half-maximal inhibitory concentration: > 100000 nM
Compound 4: a limit, no number; the forecaster's own chance of this, stated with the estimate: 5%; at least 5.8-fold (0.76 log units) between middle value and limit.
By their numbers in this assay, from the lowest: compound 2; then compound 3; then compound 1. At a limit, above all of these: compound 4.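

In this assay compound 4 reads > 100000 nM, which is a limit and not a number. The change on the carbonyl carbon gives an at least 1.9-fold higher number from compound 1 to compound 4 (0.28 log units; that floor lies within the scatter), so its floor alone does not separate the two groups. The lowering in a 4.2-fold higher number from compound 2 to compound 3 (0.62 log units; beyond the scatter), with the other ring with two hetero atoms, does not appear here on the core of compound 1.

From the compounds shown here alone, the actual value of compound 4 remains open. Also open, going by these compounds, is how 5-(4-fluorophenyl)-1,2-oxazol-3-yl reads with the 2-(4-methylpiperidin-1-yl)ethyl chain, or with a morpholine on that chain.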